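This account rests on a few compounds, and the source may have more. Where it says the series, first, only, none or still open, it means among the compounds named here.

Measured in a functional assay on HT-29 cells (Homo sapiens) for antiproliferative activity, read by sulforhodamine B assay, with a stated time of 48 h; on this read-out lower numbers stand for stronger inhibition and higher numbers for weaker inhibition:
Compound 1 `CCC(=O)Nc1cccc(S(=O)(=O)Oc2ccccc2C(C)C)c1`: 22000 nM
Compound 2 `CCCC(=O)Nc1ccc(S(=O)(=O)Oc2ccccc2C(C)C)cc1`: 4900 nM
Compound 3 `CC(C)(C)C(=O)Nc1ccc(S(=O)(=O)Oc2ccccc2I)cc1`: 9500 nM

Compound 3 stands second highest of these three numbers. Its nearest neighbour is compound 2, whose number sits within the scatter of it, so the two cannot be ranked; compound 1 is the furthest, with a higher number that lies beyond the scatter.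

Compound 4 `O=C(NCC1CCCC1)Nc1ccc(S(=O)(=O)Oc2ccccc2I)cc1` differs from compound 3 in one place: (cyclopentylmethyl)amino in place of tert-butyl on a carbonyl carbon. For the measured compounds named here, no measured pair shows this change, so its effect is unknown from the numbers at hand. Compound 4 is therefore expected to stay close to compound 3, with a step of a 1.4-fold lower number from compound 3 to compound 4 (0.13 log units; within the scatter) that is not expected to exceed the scatter in either direction. Compound 4 is estimated at 7000 nM, within a range of 2500 nM to 20000 nM.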

Compound 4, half-maximal inhibitory concentration: 7600 nM
For compound 4 the middle estimate is 1.1-fold (0.04 log units) below the measured one; low and high end bracket the measured number.
By their numbers in this assay, from the lowest: compounds 2, 4 and 3 (each within the scatter of the next); then compound 1.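

In this assay, (cyclopentylmethyl)amino in place of tert-butyl on a carbonyl carbon gives a 1.3-fold lower number from compound 3 to compound 4 (0.10 log units; within the scatter) and so shows that this place accepts a larger group, with a five-membered ring and a hydrogen-bond donor, without a step beyond the scatter. The earlier compounds shown here offered no pair differing in this one place. Nothing at hand bears on the reason for this result.

On these data alone, whether a phenyl group, a morpholine ring, a carboxylic acid or a longer chain on the same carbonyl carbon would move the number beyond the scatter stays open.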